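A few compounds are considered here, and "the series" means these few. Any claim that something is new, unique, unknown or untested is made for them only; others in the source may bear on it.

Compound 1 `COc1cc(-c2nn(-c3cccc(NC(=O)Nc4ccc(Cl)c(Cl)c4)c3)cc2-c2ccncc2)ccc1Cl`: 151 nM
Compound 2 `O=C(Nc1cccc(-n2cc(-c3ccncc3)c(-c3ccc(Cl)c(O)c3)n2)c1)Nc1ccc(Cl)c(Cl)c1`: 679 nM
Compound 3 `COc1cc(-c2nn(-c3cccc(NC(=O)Nc4cccc(C(F)(F)F)c4)c3)cc2-c2ccncc2)ccc1Cl`: 557 nM

All three share one core and were tested in a functional assay on HOP-92 cells (Homo sapiens) for inhibition, read by sulforhodamine B assay, with a stated time of 48 h; on this read-out higher numbers stand for weaker inhibition of growth and lower numbers for stronger inhibition of growth. Compound 2 gives the highest of the three numbers; compound 3 sits within the scatter of it, while compound 1 lies furthest away, the step of a 4.5-fold higher number from compound 1 to compound 2 (0.65 log units; beyond the scatter) being beyond the scatter. Compound 4 `O=C(Nc1cccc(-n2cc(-c3ccncc3)c(-c3ccc(Cl)c(O)c3)n2)c1)Nc1ccc(Cl)c(C(F)(F)F)c1` is compound 2 with a single change: trifluoromethyl in place of chloro on an aromatic carbon. Going by the values given here, only one measured step touches the same aryl group on the urea: a 3.7-fold higher number from compound 1 to compound 3 (0.57 log units; beyond the scatter), in which the whole 3,4-dichlorophenyl became 3-(trifluoromethyl)phenyl and the number rose modestly. The change to compound 4 is smaller than that, since the chloro remains and only the group ortho to it turns into trifluoromethyl; the phenol of compound 2 is untouched. Among the compounds with values here, no measured pair shows exactly this swap. A step of a 1.2-fold higher number from compound 2 to compound 4 (0.07 log units; within the scatter) is therefore expected in this assay, small and most likely not clearly beyond the scatter, with any drift toward weaker growth inhibition. Compound 4 is estimated at 800 nM, with a range from 300 nM to 2200 nM.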

Compound 4, concentration for 50% growth inhibition: 376 nM
The estimate for compound 4 lay 2.1-fold (0.33 log units) above the measured number; the measured number falls inside the stated range.
By their numbers in this assay, from the lowest: compound 1; then compounds 4, 3 and 2 (each within the scatter of the next).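

In this assay, placing trifluoromethyl where a chloro group stood on the aryl group of the urea gives a 1.8-fold lower number from compound 2 to compound 4 (0.26 log units; within the scatter), so 3,4-dichlorophenyl and 4-chloro-3-(trifluoromethyl)phenyl cannot be told apart on this read-out. The earlier step, a 3.7-fold higher number from compound 1 to compound 3 (0.57 log units; beyond the scatter), replaced the whole aryl group and lost the chloro group at the same time; the rise in number seen there does not appear as a clear step here, where the chloro group stays, although the two steps start from different compounds, one carrying a methoxy group and the other a hydroxy group. No measurement of any property of these groups accompanies the result, so the data offer no explanation for it.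

The compounds shown leave open whether the same swap would read the same way with the methoxy group of compound 1 on the other aryl ring, where the starting number is lower. They also leave open how other groups at this place on the urea's aryl ring would read, such as a nitrile, a methyl group, an amine or a carboxylic acid.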